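Chloro on the anilide ring of the nitrobenzofurazan ester series

This account rests on a few compounds, and the source may have more. Where it says the series, first, only, none or still open, it means among the compounds named here.

Measured compounds:
compound 1 `O=C(CCC(=O)OCCCCCCSc1ccc([N+](=O)[O-])c2nonc12)Nc1ccccc1`, a functional assay on A549 cells (Homo sapiens) for inhibition, read by MTT assay, with a stated time of 72 h; a lower number here means a stronger inhibitor, a higher number a weaker inhibitor: 1960 nM
compound 2 `O=C(CCC(=O)OCCCCCCSc1ccc([N+](=O)[O-])c2nonc12)Nc1ccccc1Cl`, this assay: 2750 nM
compound 3 `Cc1ccccc1NC(=O)CCC(=O)OCCCCCCSc1ccc([N+](=O)[O-])c2nonc12`, this assay: 4200 nM

Compound 1 gives the lowest number of the three, though its gap to compound 2 is within the scatter and only compound 3 sits beyond it. Compound 4 `O=C(CCC(=O)OCCCCCCSc1ccc([N+](=O)[O-])c2nonc12)Nc1cccc(Cl)c1` is not yet measured. Against compound 1 it differs by chloro in place of hydrogen on an aromatic carbon.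

Among the measured compounds shown here, two measured steps bear on the change. The step of a 1.4-fold higher number from compound 1 to compound 2 (0.15 log units; within the scatter) also puts chloro in place of hydrogen on an aromatic carbon of the same ring and does not leave the scatter. The step of a 2.1-fold higher number from compound 1 to compound 3 (0.33 log units; beyond the scatter) puts methyl in place of hydrogen on that ring and is a modest weakening. Both substitutions on this ring therefore move the number up slightly or not at all, and nothing in the three measured compounds shows a gain.

Compound 4 is accordingly expected to land close to compound 1, with a step of a 1.2-fold higher number from compound 1 to compound 4 (0.09 log units; within the scatter), giving an estimate of 2400 nM within the range 1200 nM to 4800 nM.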

Compound 4, half-maximal inhibitory concentration: 5290 nM
For compound 4 the middle estimate is 2.2-fold (0.34 log units) below the measured one; measured number outside the range, above it.
By their numbers in this assay, from the lowest: compounds 1, 2, 3 and 4 (each within the scatter of the next, the first and the last beyond it).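

In this assay, chloro meta to a large group on the anilide ring gives a 2.7-fold higher number from compound 1 to compound 4 (0.43 log units; beyond the scatter) and so passes the scatter as a modest weakening, whereas the other chloro step, a 1.4-fold higher number from compound 1 to compound 2 (0.15 log units; within the scatter), does not. The two chloro placements still cannot be separated, since a 1.9-fold higher number from compound 2 to compound 4 (0.28 log units; within the scatter), and compound 4 also stays close to the methyl compound, with a 1.3-fold higher number from compound 3 to compound 4 (0.10 log units; within the scatter). Nothing shown gives a measured reason for the step from hydrogen to chloro at this position.

Still open, from the compounds shown here alone, is whether this position accepts any group with a gain over hydrogen, for example a methoxy group, an amine or a carboxylic acid. Also open, going by these compounds, is whether the step holds with a shorter or longer chain in place of the hexyl linker of the shared core.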